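Propyl Replaces Nitrile on the Benzamide Ring

A few compounds are considered here, and "the series" means these few. Any claim that something is new, unique, unknown or untested is made for them only; others in the source may bear on it.

Two amides on a shared core have been measured in a functional assay on MDA-MB-231 cells (Homo sapiens) for antiproliferative activity, read by CCK-8 assay, with a stated time of 72 h; on this read-out higher numbers stand for weaker inhibition and lower numbers for stronger inhibition. Compound 1 `COc1ccc(C(=O)Nc2cccc(-c3oc4cc(-c5ccc(F)cc5)ccc4c(=O)c3O)c2)cc1` gives 16500 nM. Among the measured compounds shown here, compound 2 `N#Cc1ccc(C(=O)Nc2cccc(-c3oc4cc(-c5ccc(F)cc5)ccc4c(=O)c3O)c2)cc1` gives 11600 nM in this assay; compound 1 is its only neighbour on the record, and the two numbers lie within the scatter of each other. For the measured compounds named here, the single step documented, a 1.4-fold lower number from compound 1 to compound 2 (0.15 log units; within the scatter), is the only guide to this position on the ring. Compound 3 `CCCc1ccc(C(=O)Nc2cccc(-c3oc4cc(-c5ccc(F)cc5)ccc4c(=O)c3O)c2)cc1` has not yet been measured; it differs from compound 2 by propyl in place of cyano on an aromatic carbon. Going by the values given here, no measured step involves a propyl group, and the one step that exists stayed inside the scatter, so a shift in either direction beyond the scatter in this assay cannot be supported from what is known. The expected step is therefore small: a 1.2-fold higher number from compound 2 to compound 3 (0.08 log units; within the scatter). Compound 3 is accordingly estimated at 14000 nM, with a range from 5000 nM to 40000 nM.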

Compound 3, half-maximal inhibitory concentration: 32200 nM
Compound 3: the middle estimate sits 2.3-fold (0.36 log units) below what was measured; low and high end bracket the measured number.
By their numbers in this assay, from the lowest: compounds 2, 1 and 3 (each within the scatter of the next, the first and the last beyond it).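

In this assay, among the compounds shown here, propyl in place of cyano gives a 2.8-fold higher number from compound 2 to compound 3 (0.44 log units; beyond the scatter) and is the first step at this position to pass the scatter, so the group held here can change the read-out, if only modestly. Propyl in place of methoxy gives a 2.0-fold higher number from compound 1 to compound 3 (0.29 log units; within the scatter) and stays inside the scatter, which means that of the three groups compared, only nitrile and propyl are separated. Nothing measured on these compounds offers an explanation for this difference.

As far as these compounds go, whether an amine, a carboxylic acid or a longer chain such as butyl at this position would move the number further up, or bring it down past that of compound 2, remains open. The compounds shown also leave open whether the step from nitrile to propyl would hold on any other core.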